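From a Hydroxyphenyl-Capped Alkyne to a Hexyl-Capped One

The compounds below may be only part of what the source reports. "The series", "measured", "known", "first", "only" and "open" are said of these compounds alone.

Compound 1 `Cn1cncc1C(OCc1ccc(C#N)cc1C#Cc1cccc(O)c1)c1ccc(C#N)cc1` is the starting point. In a functional assay on NIH3T3 cells (Mus musculus) (on this read-out lower numbers stand for an effect already at smaller amounts and higher numbers for an effect only at larger amounts of compound), compound 1 gives only a limit of the assay, > 0.1 nM, and no number. Two measured neighbours share its core: compound 2 `Cn1cncc1C(OCc1ccc(C#N)cc1C#CC(C)(C)C)c1ccc(C#N)cc1` gives 76.9 nM and compound 3 `Cn1cncc1C(OCc1ccc(C#N)cc1-c1ccccc1)c1ccc(C#N)cc1` gives 140 nM; between them lies a 1.8-fold higher number from compound 2 to compound 3 (0.26 log units; within the scatter). The steps a step that the limit leaves unreadable from compound 1 to compound 2 and a step that the limit leaves unreadable from compound 1 to compound 3 cannot be sized because of the limit (the limit of > 0.1 nM in this assay, at which 1 of the 3 values shown sits). The unmeasured compound 4 `CCCCCCC#Cc1cc(C#N)ccc1COC(c1ccc(C#N)cc1)c1cncn1C` differs from compound 1 by hexyl in place of 3-hydroxyphenyl on a triple-bonded carbon. Like the tert-butyl of compound 2, the hexyl is a carbon chain on the alkyne, so compound 4 is expected to land near compound 2, at an estimated 80 nM (range 20 nM to 320 nM). The implied change is the estimated step that the limit leaves unreadable from compound 1 to compound 4.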

Compound 4, half-maximal effective concentration: > 0.1 nM
Compound 4: no number, only a limit; the forecaster's own chance of this, stated with the estimate: 10%; the middle value does not contradict the limit.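

Among the compounds shown here, no step to compound 4 from compound 1, compound 2 or compound 3 can be read, because compound 4 gives only a limit and no number: the limit of > 0.1 nM in this assay, at which 2 of the 4 values shown sit. Still open, as far as these compounds go, is where compound 1 and compound 4 actually stand in this assay, and so whether hexyl and 3-hydroxyphenyl differ at all.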